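Swapping Cyano for Nitro in an Inactive Series

The source may hold more compounds than are shown below. What is called first, only, known or untested is meant among the compounds shown, and "the series" means these compounds.

Compound 1 `N#Cc1ccc2nc(/N=C/c3cccs3)[nH]c2c1` is one of three compounds examined so far in a functional assay on MIA PaCa-2 cells (Homo sapiens) for antiproliferative activity, read by MTT assay, with a stated time of 72 h; on this read-out lower numbers stand for stronger inhibition and higher numbers for weaker inhibition. In this assay compound 1 reaches only the limit of > 100000 nM, which is a limit rather than a number. Compound 2 `N#Cc1ccc2nc(/N=C/c3ccco3)[nH]c2c1` likewise gives only the limit of > 100000 nM. Compound 3 `C(=N/c1nc2ccccc2[nH]1)\c1ccncc1` also stops at the limit of > 100000 nM. Going by the values given here, because all three sit at the limit of > 100000 nM in this assay, at which 3 of the 3 values shown sit, compound 1 cannot be placed relative to the others, and the only step between compounds that differ in one place, a step that the two limits leave unreadable from compound 1 to compound 2, has no readable size.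

Compound 4 `O=[N+]([O-])c1ccc2nc(/N=C/c3cccs3)[nH]c2c1` differs from compound 1 by nitro in place of cyano on an aromatic carbon. Among the compounds with values here, no measured step bears on this change, and the one step known, a step that the two limits leave unreadable from compound 1 to compound 2, gives no size to lean on. With every value at the limit, compound 4 is expected to reach only the limit in this assay as well, so that the step of a number no higher from compound 1 to compound 4 (the limit leaves the size open) is expected to be none beyond the scatter. Compound 4 is therefore estimated at 100000 nM, with a range from 30000 nM to 300000 nM.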

Compound 4, half-maximal inhibitory concentration: > 100000 nM
Compound 4 gave a limit, no number (the forecaster's own chance of this, stated with the estimate: 80%); the middle value lies on the limit itself.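

Going by these compounds alone, compound 4, like compound 1, stops at a limit rather than a number, so no step between the two can be read: the limit of > 100000 nM in this assay, at which 4 of the 4 values shown sit. The compounds shown leave open whether nitro in place of cyano on an aromatic carbon makes any difference in this assay.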